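From furan-2-yl to phenyl on a shared core

The compounds below may be only part of what the source reports. "The series", "measured", "known", "first", "only" and "open" are said of these compounds alone.

Three nucleosides frame this step, all tested in an ADME assay on MRC5 cells (Homo sapiens), read by MTT assay, with a stated time of 72 h; on this read-out higher numbers stand for weaker inhibition and lower numbers for stronger inhibition. For the measured compounds named here, compound 1 (`COc1ncnc2c1c(-c1cc3ccccc3o1)cn2[C@@H]1O[C@H](CO)[C@@H](O)[C@H]1O`) gives 65600 nM, the only actual number among them. Compound 2 (`CNc1ncnc2c1c(-c1ccoc1)cn2[C@@H]1O[C@H](CO)[C@@H](O)[C@H]1O`) reads > 100000 nM, which is a limit of the assay and not a number. Compound 3 (`Nc1nc2c(c(-c3ccco3)cn2[C@@H]2O[C@H](CO)[C@@H](O)[C@H]2O)c(=O)[nH]1`) reads > 100000 nM, also a limit. Compound 3 therefore stands at the limit of > 100000 nM in this assay, at which 2 of the 3 values shown sit.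

Compound 4 (`Nc1nc2c(c(-c3ccccc3)cn2[C@@H]2O[C@H](CO)[C@@H](O)[C@H]2O)c(=O)[nH]1`) keeps the core of compound 3 but has phenyl in place of furan-2-yl on an aromatic carbon. Going by the values given here, no two measured compounds differ in one place, so no measured step gauges this change. In this assay, among the compounds with values here, the expectation is a step no larger than the scatter, or a modest one toward stronger inhibition, with compound 1 at 65600 nM as the only guide to how far a number might fall. The estimated change is an at least 1.1-fold lower number from compound 3 to compound 4 (0.04 log units; that floor lies within the scatter). For compound 4 the expected value is 90000 nM, within an estimated range of 30000 nM to 150000 nM.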

Compound 4, half-maximal inhibitory concentration: > 100000 nM
Compound 4 ended at the assay's limit; the forecaster's own chance of this, stated with the estimate: 60%; middle value at least 1.1-fold (0.04 log units) from the limit.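

In this assay compound 4 reads > 100000 nM, which is a limit of the assay and not a number. Compound 3 also sits at a limit, so no step can be read between compound 3 and compound 4: the limit of > 100000 nM in this assay, at which 3 of the 4 values shown sit.

The compounds shown leave open whether phenyl and furan-2-yl differ at all on this shared core.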